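Replacing the benzyl group of compound 3

The source may report more compounds than this note shows. Statements on the series, on what has been measured and on what is new or still open speak of the compounds shown alone.

Measured in a functional assay on HeLa cells (Homo sapiens) for cytotoxicity, read by MTT assay, with a stated time of 48 h; on this read-out lower numbers stand for stronger inhibition and higher numbers for weaker inhibition:
- compound 1 `Cc1ccc(Cn2c(/C=C3\SC(=S)N(CC(=O)O)C3=O)nc3ccccc32)cc1`: 1280 nM
- compound 2 `Cc1ccc(Cn2c(/C=C3\SC(=S)N(CC(=O)O)C3=O)nc3ccc(F)cc32)cc1`: 3920 nM
- compound 3 `COc1ccc2nc(/C=C3\SC(=S)N(CC(=O)O)C3=O)n(Cc3ccc(C)cc3)c2c1`: 6440 nM

Compound 3 stands at the upper end of these three numbers. The nearest gap, a 1.6-fold higher number from compound 2 to compound 3 (0.22 log units; within the scatter), lies within the scatter, while the furthest, a 5.0-fold higher number from compound 1 to compound 3 (0.70 log units; beyond the scatter), lies beyond it.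

The next compound is compound 4 `COc1ccc2nc(/C=C3\SC(=S)N(CC(=O)O)C3=O)n(Cc3ccccc3F)c2c1`, and the change is 2-fluorophenyl in place of 4-methylphenyl on a saturated chain carbon bound to an aromatic nitrogen. For the measured compounds named here, no measured step touches this group. All three steps replace a substituent on an aromatic carbon elsewhere, and the remaining one, a 3.1-fold higher number from compound 1 to compound 2 (0.49 log units; beyond the scatter), is also modest. They therefore bear on this change only indirectly, as a guide to how far one replacement has moved the numbers in this assay. Going by the values given here, with no direct precedent, neither direction is favoured, and the expected step is a 1.3-fold lower number from compound 3 to compound 4 (0.11 log units; within the scatter). The estimated value for compound 4 is 5000 nM. The expected range for compound 4 runs from 2000 nM to 12000 nM.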

Compound 4, half-maximal inhibitory concentration: 28100 nM
For compound 4 the middle estimate is 5.6-fold (0.75 log units) below the measured one, and the stated range ends below it.
By their numbers in this assay, from the lowest: compound 1; then compounds 2 and 3 (each within the scatter of the next); then compound 4.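

Putting 2-fluorophenyl in place of 4-methylphenyl on the saturated chain carbon bound to an aromatic nitrogen gives a 4.4-fold higher number from compound 3 to compound 4 (0.64 log units; beyond the scatter) in this assay and shows that this position, not only the substituents on aromatic carbons elsewhere, moves the number. The two groups match in heavy atoms, hydrogen-bond donors, hydrogen-bond acceptors and net charge, yet the step lies beyond the scatter and runs towards weaker inhibition. Nothing available here accounts for the shift.

The 4-methylbenzyl group leaves and the 2-fluorobenzyl group enters in a single step, so the compounds shown do not separate the loss of the methyl from the gain of the fluoro. From the compounds shown here alone, how a plain benzyl group or a longer chain such as phenethyl would fare at this position remains open, as does whether the step would carry over to the core of compound 1.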